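Cyanoacrylamide series: phenyl for cyclopropyl on the amide carbon

This account rests on a few compounds, and the source may have more. Where it says the series, first, only, none or still open, it means among the compounds named here.

Compound 1 `CC[C@H](NC(=O)/C(C#N)=C/c1cccc(Br)n1)c1ccccc1` — 1700 nM
Compound 2 `N#C/C(=C\c1cccc(Br)n1)C(=O)NC(c1ccccc1)C1CC1` — 1600 nM
Compound 3 `N#C/C(=C\c1cccc(Br)n1)C(=O)N[C@H](c1ccccc1)C1CC1` — "not determined" (no result reported)

In a functional assay on OCI-My4 cells (Homo sapiens) for antiproliferative activity, read by MTT assay, with a stated time of 72 h (a lower number here means a stronger inhibitor, a higher number a weaker inhibitor), compound 2 gives 1600 nM, the lowest of the two numbers available. Its nearest neighbour is compound 1, which in this assay gives 1700 nM, a gap that lies within the scatter, so the two cannot be ordered. Compound 3 differs from compound 2 only in that (the fact that one of compounds 2 and 3 is drawn with a defined configuration and the other without, at the place where they differ), and for compound 3 no value was reported in this assay.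

The next compound, compound 4 `N#C/C(=C\c1cccc(Br)n1)C(=O)NC(c1ccccc1)c1ccccc1`, carries the change (phenyl in place of cyclopropyl on a saturated chain carbon bound to an amide-type nitrogen and an aromatic carbon). Among the measured compounds shown here, no comparable step between measured compounds exists here, so the size of the effect can only be guessed. Given that the ethyl of compound 1 and the cyclopropyl of compound 2 sit within the scatter of each other, the step of no change at the digits printed from compound 2 to compound 4 (within the scatter) is expected to be small and without a clear direction. Compound 4 is therefore estimated to give 1600 nM in this assay, with a range from 500 nM to 5000 nM.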

Compound 4, half-maximal inhibitory concentration: 6200 nM
The estimate for compound 4 lay 3.9-fold (0.59 log units) below the measured number, and the stated range ends below it.
By their numbers in this assay, from the lowest: compounds 2 and 1 (each within the scatter of the next); then compound 4.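

Until this point, the values of compound 1 and compound 2 lay within the scatter of each other, so nothing yet showed that this position responds to the group it carries. In this assay, among the compounds shown here, phenyl in place of cyclopropyl on the saturated chain carbon gives a 3.9-fold higher number from compound 2 to compound 4 (0.59 log units; beyond the scatter), a modest weakening and the first step here that clears the scatter, so this position does not treat all its groups alike. Nothing given here bears on the reason for this step.

The compounds shown leave open whether the weakening follows the aromatic ring itself or the move from three heavy atoms to six. They also leave open how a cyclohexyl group on this carbon, or a phenyl carrying an amine, would compare in this assay.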